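The compounds below may be only part of what the source reports. "The series", "measured", "known", "first", "only" and "open" are said of these compounds alone.

In a functional assay on HepG2 cells (Homo sapiens) for cytotoxicity, read by MTT assay, with a stated time of 48 h (on this read-out lower numbers stand for stronger inhibition and higher numbers for weaker inhibition), compound 1 `CCC(=O)N1N=C(C)CC1c1cc(Br)cc(Br)c1O` gives 41400 nM as its reading, and compound 3 `Cc1ccc(C(=O)N2N=C(c3cc4ccccc4oc3=O)CC2c2ccccc2)cc1` gives 52300 nM as its reading. These two numbers lie within the scatter of each other, so compound 3 stands level with compound 1. Compound 2 `CC1=NN(C(=O)CN2CCN(C)CC2)C(c2ccccc2O)C1` is reported as "not active" (no number reported) with no number attached.

Compound 4 `CCNCC(=O)N1N=C(c2cc3ccccc3oc2=O)CC1c1ccccc1` differs from compound 3 in one place, with (ethylamino)methyl in place of 4-methylphenyl on a carbonyl carbon is the full count of that change. Among the compounds with values here, no pair of measured compounds shows what such a change does. Compound 2 also has a nitrogen-bearing chain on a carbonyl carbon and reads "not active" (no number reported) in this series, so a result without a number remains possible for compound 4.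

No step beyond the scatter is expected in this assay in either direction. The expected step is a 1.0-fold lower number from compound 3 to compound 4 (0.02 log units; within the scatter) on this estimate. For compound 4 the expected value is 50000 nM with an estimated range from 18000 nM to 140000 nM in this read-out.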

Compound 4, half-maximal inhibitory concentration: 30600 nM
Compound 4: middle estimate off by 1.6-fold (0.21 log units), on the high side; measured number inside the range.
By their numbers in this assay, from the lowest: compounds 4, 1 and 3 (each within the scatter of the next).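

In this assay, putting (ethylamino)methyl in place of 4-methylphenyl on a carbonyl carbon gives a 1.7-fold lower number from compound 3 to compound 4 (0.23 log units; within the scatter), so this single change produces no readable shift at this position. For this pair, the six-membered aromatic ring of carbon only can leave this carbonyl carbon and a numerical reading remains, and compound 4 does not fall into the class of results without a number. No measured evidence bears on this step.

On these data alone, whether a longer chain, a dimethylamino group or a carboxylic acid on this carbonyl carbon would move the number beyond the scatter remains open. Also open, as far as these compounds go, is whether the same exchange would read the same way on a core other than that of compound 3.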